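This account rests on a few compounds, and the source may have more. Where it says the series, first, only, none or still open, it means among the compounds named here.

In a functional assay on HOS-TE85 cells (Homo sapiens) for inhibition, read by CCK-8 assay, with a stated time of 72 h (on this read-out higher numbers stand for weaker inhibition and lower numbers for stronger inhibition), compound 1 `COc1ccc(OC)c(N2C(=O)CSC2c2cccc(C(=O)NCCCCc3ccccc3)c2)c1` reads > 1000 nM, which is a limit of the assay and not a number. For the measured compounds named here, compound 2 `CC(F)(F)c1cccc(N2C(=O)CSC2c2cccc(C(=O)NCCCCc3ccccc3)c2)c1` gives 29.1 nM, the only true number so far. Compound 3 `O=C(NCCCCc1ccccc1)c1cccc(C2SCC(=O)N2c2ccc(C3CC3)cc2)c1` differs from compound 2 on the amide-type nitrogen in a ring: a group of 9 heavy atoms (9 carbon; one three-membered non-aromatic ring of carbon only, one six-membered aromatic ring of carbon only) in place of a group of 10 heavy atoms (8 carbon, 2 fluorine; one six-membered aromatic ring of carbon only), on an amide-type nitrogen in a ring. Going by the values given here, one measured step bears on this change, an at least 34-fold lower number from compound 1 to compound 2 (1.53 log units; beyond the scatter). It is a large step at the same place, so the group on this nitrogen can move the read-out strongly in this assay. Yet that single step sets no trend for a 4-cyclopropylphenyl group. Starting from compound 2 at 29.1 nM, a modest loss of strength is expected, well short of that large step, and the expected change is a 2.1-fold higher number from compound 2 to compound 3 (0.31 log units; beyond the scatter). For compound 3 the estimated value is 60 nM, with an expected range from 15 nM to 300 nM.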

Compound 3, half-maximal inhibitory concentration: 217 nM
Estimate against measurement, compound 3: 3.6-fold (0.56 log units) below; the range from low to high includes it.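

On the amide-type nitrogen, 4-cyclopropylphenyl in place of the group of compound 2 gives a 7.5-fold higher number from compound 2 to compound 3 (0.87 log units; beyond the scatter) in this assay, so a group of carbon only still gives a true number here but does not match compound 2. Against the other end of the series, 4-cyclopropylphenyl in place of 2,5-dimethoxyphenyl gives an at least 4.6-fold lower number from compound 1 to compound 3 (0.66 log units; beyond the scatter), which places compound 3 between the other two, with both steps beyond the scatter. The full size of that second step stays unknown because compound 1 rests on a limit and not on a number: the limit of > 1000 nM in this assay, at which 1 of the 3 values shown sits.

On these data alone, how a plain phenyl, a 4-chlorophenyl or a pyridyl group would read on this nitrogen remains open. The three groups shown differ from one another in more than one feature, so no single feature can be tied to these steps.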